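Swapping Cyclohexyl for Methoxyphenyl on the Amide Nitrogen

The source may hold more compounds than are shown below. What is called first, only, known or untested is meant among the compounds shown, and "the series" means these compounds.

Compound 2 `CCOC(=O)C1=Cc2ccccc2OC1(OCc1cn(CC(=O)NC2CCCCC2)nn1)C(F)(F)F` gives 9900 nM in a functional assay on A549 cells (Homo sapiens) for inhibition, read by MTT assay, with a stated time of 24 h; on this read-out lower numbers stand for stronger inhibition and higher numbers for weaker inhibition. Among the three measured numbers this is the second highest. Compound 1 `CCOC(=O)C1=Cc2ccccc2OC1(OCc1cn(-c2ccc(F)cc2)nn1)C(F)(F)F` gives 7300 nM, and the change a 1.4-fold higher number from compound 1 to compound 2 (0.13 log units; within the scatter) altered only a group on an aromatic nitrogen. Compound 3 `Cc1ccc(-c2cc(COC3(C(F)(F)F)Oc4ccccc4C=C3C(=O)O)on2)cc1` gives 51200 nM, which lies beyond the scatter from compound 2. Compound 4 `CCOC(=O)C1=Cc2ccccc2OC1(OCc1cn(CC(=O)Nc2ccc(OC)cc2)nn1)C(F)(F)F` differs from compound 2 by one change: 4-methoxyphenyl in place of cyclohexyl on an amide-type nitrogen. Among the measured compounds shown here, no measured step touches this amide-type nitrogen; the single known step sits elsewhere and stayed within the scatter. With nothing pointing in either direction, compound 4 is expected to give 9000 nM in this assay, with a range from 3000 nM to 30000 nM. The step of a 1.1-fold lower number from compound 2 to compound 4 (0.04 log units; within the scatter) is therefore expected to be none beyond the scatter.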

Compound 4, half-maximal inhibitory concentration: 29400 nM
For compound 4 the middle estimate is 3.3-fold (0.51 log units) below the measured one, within the range that was stated.
By their numbers in this assay, from the lowest: compounds 1 and 2 (each within the scatter of the next); then compounds 4 and 3 (each within the scatter of the next).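

Among the compounds shown here, the group on the amide-type nitrogen matters: in this assay, 4-methoxyphenyl in place of cyclohexyl gives a 3.0-fold higher number from compound 2 to compound 4 (0.47 log units; beyond the scatter), the first step at this position and one beyond the scatter. Compound 2 lies within the scatter of compound 1, yet the ((4-methoxyphenyl)carbamoyl)methyl group gives a 4.0-fold higher number from compound 1 to compound 4 (0.61 log units; beyond the scatter), so this side chain does not tolerate every group at its far end. Nothing shown explains this step.

On these data alone, it remains open whether the step follows the aromatic ring or its methoxy group. A plain phenyl on this nitrogen would separate the two.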